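A few compounds are considered here, and "the series" means these few. Any claim that something is new, unique, unknown or untested is made for them only; others in the source may bear on it.

Compound 1 `OC(c1ccc(Cl)cc1)(c1cccnc1)c1ccccc1Cl`: 61300 nM
Compound 2 `Clc1ccc(C(c2cccnc2)c2ccccc2Cl)cc1`: 62300 nM
Compound 3 `[O-][n+]1cncc(C(O)(c2ccc(Cl)cc2)c2ccccc2Cl)c1`: > 100000 nM, a limit of the assay and not a number

Among the measured compounds shown here, in an ADME assay on L6 cells (Rattus norvegicus) for cytotoxicity, read by resazurin assay, with a stated time of 72 h (on this read-out lower numbers stand for stronger inhibition and higher numbers for weaker inhibition), compound 1 sits within the scatter of compound 2, and these are the only two exact numbers. Compound 3 has no exact number to compare, since its > 100000 nM is a limit.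

Compound 4 `Cc1ccccc1C(O)(c1ccc(Cl)cc1)c1cccnc1` departs from compound 1 in one place: methyl in place of chloro on an aromatic carbon. For the measured compounds named here, no measured step changes that group, so the evidence is indirect. Replacing hydroxy with hydrogen gave a 1.0-fold higher number from compound 1 to compound 2 (0.01 log units; within the scatter). The change of aromatic ring gave an at least 1.6-fold higher number from compound 1 to compound 3 (0.21 log units; that floor lies within the scatter). Neither step shows a shift beyond the scatter, so no step beyond the scatter is expected in this assay for this exchange. The expected change is a 1.1-fold higher number from compound 1 to compound 4 (0.03 log units; within the scatter). Compound 4 is estimated at 65000 nM, with an expected range of 35000 nM to 100000 nM.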

Compound 4, half-maximal inhibitory concentration: 82000 nM
For compound 4 the middle estimate is 1.3-fold (0.10 log units) below the measured one; measured number inside the range.
By their numbers in this assay, from the lowest: compounds 1, 2 and 4 (each within the scatter of the next). At a limit, above all of these: compound 3.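

In this assay, the exchange of 2-chlorophenyl to 2-methylphenyl gives a 1.3-fold higher number from compound 1 to compound 4 (0.13 log units; within the scatter). Among the compounds shown here, the earlier steps changed the hydroxy group and the other aromatic ring, so this is the first reading for the six-membered aromatic ring of carbon only, on an aromatic carbon ortho to a large group. At this place, methyl and chloro give numbers within the scatter of each other, and neither group stands apart from the other in this assay.

Going by these compounds, whether an amine, a carboxylic acid or a longer chain at this place would move the number beyond the scatter stays open. The room for reading such a shift is also bounded, as compound 3 gives a limit of the assay and not a number: the limit of > 100000 nM in this assay, at which 1 of the 4 values shown sits.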